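The source may hold more compounds than are shown below. What is called first, only, known or untested is meant among the compounds shown, and "the series" means these compounds.

Compound 1 `Cc1n[nH]c2c1C(c1ccc(N(C)C)cc1)C(C(=O)O)=C(N)N2` carries a carboxy group on its shared core. In a functional assay on HeLa cells (Homo sapiens) for cytotoxicity, read by MTT assay, with a stated time of 48 h (on this read-out lower numbers stand for stronger inhibition and higher numbers for weaker inhibition), compound 1 gives 33600 nM, the highest of the three numbers seen so far, with the nearest one being compound 2 `Cc1n[nH]c2c1C(c1ccc(N(C)C)cc1)C(C(=O)N/N=C/c1ccc(Cl)cc1)=C(N)N2` at 31700 nM, where the step of a 1.1-fold lower number from compound 1 to compound 2 (0.03 log units; within the scatter) lies within the scatter. Compound 3 `Cc1n[nH]c2c1C(c1ccc(N(C)C)cc1)C(C(=O)NNc1cc([N+](=O)[O-])ccc1[N+](=O)[O-])=C(N)N2` gives 8520 nM, a number well below that of compound 1 and beyond the scatter.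

Compound 4 `Cc1n[nH]c2c1C(c1ccc(N(C)C)cc1)C=C(N)N2` differs from compound 1 in one place: hydrogen in place of carboxy on a double-bonded ring carbon. Within the data shown here, none of the measured steps removes the carboxy outright. Among the measured compounds shown here, the one single-site step, a 1.1-fold lower number from compound 1 to compound 2 (0.03 log units; within the scatter), exchanged one oxygen on a carbonyl carbon for a larger group and barely moved the number, while the larger replacement in compound 3 lowered it. That offers no clear direction for a bare hydrogen. Compound 4 is therefore expected to stay near compound 1, with a 1.0-fold higher number from compound 1 to compound 4 (0.02 log units; within the scatter) not beyond the scatter. In this assay compound 4 is estimated at 35000 nM, within a range from 12000 nM to 100000 nM.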

Compound 4, half-maximal inhibitory concentration: 27400 nM
The estimate for compound 4 lay 1.3-fold (0.11 log units) above the measured number, within the range that was stated.
By their numbers in this assay, from the lowest: compound 3; then compounds 4, 2 and 1 (each within the scatter of the next).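

Bare hydrogen on this double-bonded ring carbon gives a 1.2-fold lower number from compound 1 to compound 4 (0.09 log units; within the scatter) in this assay and so shows, as no earlier compound could, that the shared core holds its level in this read-out with the carboxy gone. On the printed values, compound 3 gives 8520 nM and compound 4 gives 27400 nM, so among these compounds a lower number goes only with the dinitrophenyl hydrazide of compound 3, and compound 2 goes against any rule that a large group here lowers the number. Nothing available explains this result.

As far as these compounds go, whether a small group here, such as a methyl group, a nitrile or a primary amide, would fall with compound 1 and compound 4 or nearer compound 3 stays open. So does whether a simple ester, or a hydrazide without an aromatic ring, would give a lower number.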